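Swapping an amide link for an ester link

A few compounds are considered here, and "the series" means these few. Any claim that something is new, unique, unknown or untested is made for them only; others in the source may bear on it.

- Compound 1 `CCCC(C)C(=O)NCC(C)(C)CC1=C(O)C(=O)c2ccccc2C1=O`: 47100 nM
- Compound 2 `CCCCCCC(C)C(=O)NCC(C)(C)CC1=C(O)C(=O)c2ccccc2C1=O`: 23700 nM
- Compound 3 `CCCCCCCCCC(=O)NCC(C)(C)CC1=C(O)C(=O)c2ccccc2C1=O`: 18500 nM

All three compounds were measured in a functional assay on KB cells (Homo sapiens) for cytotoxicity, read by resazurin assay, with a stated time of 3 days; on this read-out lower numbers stand for stronger inhibition and higher numbers for weaker inhibition. Compound 1 stands at the upper end of these numbers. Its nearest neighbour gives a 2.0-fold lower number from compound 1 to compound 2 (0.30 log units; within the scatter), while its furthest gives a 2.5-fold lower number from compound 1 to compound 3 (0.41 log units; beyond the scatter).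

Compound 4 `CCCCCCC(=O)OCC(C)(C)CC1=C(O)C(=O)c2ccccc2C1=O` keeps the shared core but changes the side chain: (hexylcarbonyl)oxy in place of ((1-methylbutyl)carbonyl)amino on a saturated chain carbon, three bonds along the chain from a double-bonded ring carbon. In words, this is (hexylcarbonyl)oxy in place of ((1-methylbutyl)carbonyl)amino on a saturated chain carbon, three bonds along the chain from a double-bonded ring carbon.

Within the data shown here, no measured compound makes the swap from the amino link to the oxy link, so that half of the change is untested here. Among the measured compounds shown here, the only guide is the chain on the carbonyl carbon. Changing that chain moved the number little in the steps above, and the remaining pair gives a 1.3-fold lower number from compound 2 to compound 3 (0.11 log units; within the scatter). Compound 4 is therefore expected to land near these compounds, with a small move toward lower numbers in this assay. The expected change is a 1.7-fold lower number from compound 1 to compound 4 (0.24 log units; within the scatter). The untested link makes this uncertain, so the expected range is wide. For compound 4 the estimated value is 27000 nM. The estimated range for compound 4 runs from 11000 nM to 65000 nM.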

Compound 4, half-maximal inhibitory concentration: 14400 nM
For compound 4 the middle estimate is 1.9-fold (0.27 log units) above the measured one; the measured number falls inside the stated range.
By their numbers in this assay, from the lowest: compounds 4, 3, 2 and 1 (each within the scatter of the next, the first and the last beyond it).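

The ester link is tolerated at this position: in this assay the swap gives a 3.3-fold lower number from compound 1 to compound 4 (0.51 log units; beyond the scatter), so the number moves clearly rather than staying within the scatter, as it did for the step from compound 2 to compound 3. The group that enters has 0 hydrogen-bond donors where the group that leaves has 1, so the amide hydrogen is not needed for compound 4 to reach the same range as compound 3, the two lying within the scatter of each other. Nothing available explains why the number moves with this change.

Going by these compounds, the swap alters the link and the chain together, so whether the shift belongs to the oxy link or to the hexyl chain stays open, and only a pair with the same chain on both links could separate them, such as a hexyl chain on the amide or a 1-methylbutyl chain on the ester. Also open, on these data alone, is how a longer chain on the ester, such as nonyl, or a carboxylic acid at the end of the chain would read in this assay.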